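The compounds below may be only part of what the source reports. "The series", "measured", "known", "first", "only" and "open" are said of these compounds alone.

Measured compounds:
compound 1 `Oc1nc2nonc2nc1Nc1ccc(OCC(F)(F)F)cc1` — 42300 nM
compound 2 `Oc1nc2nonc2nc1Nc1ccc(OCc2ccccc2)cc1` — 2400 nM
compound 3 `CCCCCCc1ccc(Nc2nc3nonc3nc2O)cc1` — 4700 nM

All three were tested in an assay on mitochondria from L6 cells (Rattus norvegicus) for activation, with a stated time of 90 min; a higher number here means that more compound is needed for the effect, a lower number that less compound is needed. Compound 3 stands second highest of the three numbers: its nearest neighbour is compound 2, at a 2.0-fold higher number from compound 2 to compound 3 (0.29 log units; within the scatter), and its furthest is compound 1, at a 9.0-fold lower number from compound 1 to compound 3 (0.95 log units; beyond the scatter). Compound 2 and compound 3 thus sit together, while compound 1 lies well apart from both.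

The next compound, compound 4 `Oc1nc2nonc2nc1Nc1ccc(F)cc1`, differs from compound 3 in one place: fluoro in place of hexyl on an aromatic carbon. Among the compounds with values here, the step that bears most on this change is the one from compound 1 to compound 3, where hexyl in place of 2,2,2-trifluoroethoxy gave a 9.0-fold lower number from compound 1 to compound 3 (0.95 log units; beyond the scatter); the step from compound 1 to compound 2, an 18-fold lower number from compound 1 to compound 2 (1.25 log units; beyond the scatter), points the same way, in that the compound with the smaller group on that aromatic carbon gave the higher number. Replacing hexyl with fluoro, a group of one heavy atom, is therefore expected to move compound 4 back towards the number of compound 1, and the expected step is an 8.5-fold higher number from compound 3 to compound 4 (0.93 log units; beyond the scatter). Compound 4 is estimated at 40000 nM, in a range from 10000 nM to 150000 nM.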

Compound 4, half-maximal effective concentration: 38600 nM
Compound 4: middle estimate off by 1.0-fold (0.02 log units), on the high side, within the range that was stated.
By their numbers in this assay, from the lowest: compounds 2 and 3 (each within the scatter of the next); then compounds 4 and 1 (each within the scatter of the next).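

In this assay, the change to fluoro undoes what hexyl had gained (an 8.2-fold higher number from compound 3 to compound 4 (0.91 log units; beyond the scatter)), and the comparison with benzyloxy on the same aromatic carbon gives a step of similar direction (a 16-fold higher number from compound 2 to compound 4 (1.21 log units; beyond the scatter)), so a long or ring-bearing group is not merely tolerated at this position but goes with the lower numbers among these compounds. The new information lies in the comparison of fluoro with 2,2,2-trifluoroethoxy (a 1.1-fold lower number from compound 1 to compound 4 (0.04 log units; within the scatter)): this step lies within the scatter, so a group of one heavy atom and the larger fluorinated ether cannot be told apart, and group size alone does not order the four compounds, with compound 1 going against such a reading. The two groups with the higher numbers both carry fluorine while hexyl and benzyloxy carry none, but no measurement shown here accounts for the differences between these compounds.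

Size and the presence of fluorine therefore remain entangled across these four compounds. A plain ethoxy, a methyl or a butyl chain on this aromatic carbon would show whether the number follows chain length or fluorine, and whether the change from the higher to the lower numbers is gradual or abrupt.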